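Trifluoromethyl in place of nitro: compound 3 to compound 4

This account rests on a few compounds, and the source may have more. Where it says the series, first, only, none or still open, it means among the compounds named here.

Values measured in an ADME assay on L6 cells (Rattus norvegicus) for cytotoxicity, read by fluorescence and resazurin assay, with a stated time of 72 h; on this read-out higher numbers stand for lower toxicity in this test and lower numbers for higher toxicity in this test:
- compound 1 `Clc1ccc(-c2c[nH]cc2C(c2ccc(Cl)cc2)n2ccnc2)cc1` gives 4830 nM
- compound 2 `N#Cc1ccc(-c2c[nH]cc2C(c2ccc(Cl)cc2Cl)n2ccnc2)cc1` gives 15000 nM
- compound 3 `O=[N+]([O-])c1ccc(-c2c[nH]cc2C(c2ccc(Cl)cc2Cl)n2ccnc2)cc1` gives 16900 nM

Compound 3 sits level with compound 2 at the top of this small set, the two lying within the scatter of each other. Within the data shown here, compound 1 lies lower than compound 3, beyond the scatter, but no single-place step links compound 1 to the other two.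

The next structure is compound 4 `FC(F)(F)c1ccc(-c2c[nH]cc2C(c2ccc(Cl)cc2Cl)n2ccnc2)cc1`, with trifluoromethyl in place of nitro on an aromatic carbon, para to a large group: trifluoromethyl in place of nitro on an aromatic carbon.

Among the measured compounds shown here, one measured step bears on this change: a 1.1-fold higher number from compound 2 to compound 3 (0.05 log units; within the scatter), with nitro in place of cyano on an aromatic carbon. For the measured compounds named here, that step stayed within the scatter, but no trifluoromethyl compound has been measured yet, so the evidence is thin. The expected step is a 1.2-fold lower number from compound 3 to compound 4 (0.08 log units; within the scatter), with nothing expected beyond the scatter and no firm direction. For compound 4 the estimated value is 14000 nM, with an expected range from 6000 nM to 30000 nM.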

Compound 4, half-maximal cytotoxic concentration: 9400 nM
For compound 4 the middle estimate is 1.5-fold (0.17 log units) above the measured one; the range from low to high includes it.
By their numbers in this assay, from the lowest: compounds 1, 4, 2 and 3 (each within the scatter of the next, the first and the last beyond it).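

In this assay, trifluoromethyl in place of nitro on this aromatic carbon, para to a large group, gives a 1.8-fold lower number from compound 3 to compound 4 (0.25 log units; within the scatter), and trifluoromethyl in place of nitrile gives a 1.6-fold lower number from compound 2 to compound 4 (0.20 log units; within the scatter). With a trifluoromethyl compound now measured, nitrile, nitro and trifluoromethyl all lie within the scatter of one another at this position, so none of these exchanges has yet produced a step beyond the scatter on this read-out. The available data offer no measurement that bears on the size of these steps.

As far as these compounds go, whether an amine or a carboxylic acid on this same carbon would give a step beyond the scatter remains open. Compound 1 differs from the other compounds in more than one place, so the source of its separation from compound 3 also remains unresolved.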